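A few compounds are considered here, and "the series" means these few. Any claim that something is new, unique, unknown or untested is made for them only; others in the source may bear on it.

Compound 1 `CC(C)(C)c1ccc(OC/C(F)=C\CN)cc1`: 6400 nM
Compound 2 `NC/C=C(/F)COc1ccc(OC(F)(F)F)cc1`: 70 nM
Compound 3 `NC/C=C(/F)COc1ccc(C(F)(F)F)cc1`: 130 nM

All three numbers come from an assay on isolated protein for inhibition of Amine oxidase [flavin-containing] B (Homo sapiens), read by Amplex Red; on this read-out lower numbers stand for stronger inhibition and higher numbers for weaker inhibition. Compound 3 stands second highest of the three: its nearest neighbour is told by a 1.9-fold higher number from compound 2 to compound 3 (0.27 log units; within the scatter), its furthest by a 49-fold lower number from compound 1 to compound 3 (1.69 log units; beyond the scatter). Compound 4 `NC/C=C(/F)COc1ccc(C(N)=O)cc1` arises from compound 3 through one change, (carbamoyl in place of trifluoromethyl on an aromatic carbon). For the measured compounds named here, no measured step tests this group. Going by the values given here, the steps of a 91-fold lower number from compound 1 to compound 2 (1.96 log units; beyond the scatter) and a 49-fold lower number from compound 1 to compound 3 (1.69 log units; beyond the scatter) show only that the group at this place can move the result by a large amount, so a sizeable step in either direction is possible. The expected outcome in this assay is a 7.7-fold higher number from compound 3 to compound 4 (0.89 log units; beyond the scatter), toward a higher number. Compound 4 is therefore estimated at 1000 nM, with a range from 200 nM to 6000 nM.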

Compound 4, half-maximal inhibitory concentration: > 30000 nM
Compound 4 ended at the assay's limit; the forecaster's own chance of this, stated with the estimate: 5%; middle value at least 30-fold (1.47 log units) away from the limit.
By their numbers in this assay, from the lowest: compounds 2 and 3 (each within the scatter of the next); then compound 1. At a limit, above all of these: compound 4.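

In this assay, compound 4 reads only as a limit of the assay, not as a number: the limit of > 30000 nM in this assay, at which 1 of the 4 values shown sits. Even so, carbamoyl on this aromatic carbon is far poorer than the two fluorinated groups, with an at least 230-fold higher number from compound 3 to compound 4 (2.36 log units; beyond the scatter) and an at least 420-fold higher number from compound 2 to compound 4 (2.63 log units; beyond the scatter), although it has fewer heavy atoms than trifluoromethyl. It also falls behind tert-butyl, with an at least 4.6-fold higher number from compound 1 to compound 4 (0.67 log units; beyond the scatter), so tert-butyl is no longer the poorest group seen at this place.

From the compounds shown here alone, how far beyond the limit compound 4 truly lies stays open. Also open, going by these compounds, is whether an amine, a nitrile or a carboxylic acid here would behave like carbamoyl or like trifluoromethyl.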